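The source may report more compounds than this note shows. Statements on the series, on what has been measured and on what is new or still open speak of the compounds shown alone.

Going by the values given here, in a functional assay on PC-12 cells (Rattus norvegicus) for cytotoxicity, read by MTT assay, with stated times of 2 h and 24 h, tested at 5 uM (on this read-out lower numbers stand for a weaker effect and higher numbers for a stronger effect at the one concentration tested), compound 2 `Cc1ccc(-n2nc(-c3ccc(C(F)(F)F)cc3O)nc2-c2ccccc2O)c(C)c1` gives 93.3%, and compound 1 `CC(C)c1ccc(-n2nc(-c3ccc(C(F)(F)F)cc3O)nc2-c2ccccc2O)cc1` gives 100% in this assay; the only step measured so far, a number 6.7 percentage points lower from compound 1 to compound 2 (within the scatter), sits within the scatter, so the two numbers cannot be told apart. Compound 3 `Cc1cc(C)cc(-n2nc(-c3ccc(C(F)(F)F)cc3O)nc2-c2ccccc2O)c1` differs from compound 2 in one respect: 3,5-dimethylphenyl in place of 2,4-dimethylphenyl on an aromatic nitrogen. Among the compounds with values here, no measured step rearranges two methyl groups on the same ring, and the one step known was small. The expected step is about a number 1.7 percentage points higher from compound 2 to compound 3 (within the scatter), nothing beyond the scatter. Compound 3 is therefore estimated at 95%, within 85% to 100%.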

Compound 3, a percentage reported as activity, at one concentration (the size of the read-out at that concentration, not a potency): 102%
Estimate against measurement, compound 3: 7 percentage points below; measured number outside the range, above it.
By their numbers in this assay, from the lowest: compounds 2, 1 and 3 (each within the scatter of the next).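

Rearranging the two methyl groups, with 3,5-dimethylphenyl in place of 2,4-dimethylphenyl on the aromatic nitrogen, gives a number 8.7 percentage points higher from compound 2 to compound 3 (within the scatter) in this assay and so changes the read-out by no more than the scatter. Likewise, 3,5-dimethylphenyl in place of 4-isopropylphenyl gives a number 2 percentage points higher from compound 1 to compound 3 (within the scatter) on the same read-out, so these three groups cannot be told apart at this position. No measured evidence bears on this result. The compounds shown leave open whether a phenyl group carrying an amine or a carboxylic acid at this position would give a number distinct from these three.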